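Fluoro for Chloro on the Benzylsulfanyl Arm

The compounds below may be only part of what the source reports. "The series", "measured", "known", "first", "only" and "open" are said of these compounds alone.

The two measured compounds share one core, first seen in compound 1 `CC1=C(C(=O)Nc2ccc([N+](=O)[O-])cc2)C(c2ccc(Br)cc2)N=C(SCc2ccccc2)N1`. In a functional assay on the whole organism (artery, strain albino) with Rattus norvegicus as the target, with a stated time of 240 min, at a dose of 10 mg/kg by the oral route (on this read-out lower numbers stand for less inhibition and higher numbers for more inhibition at the one dose given (going by the name of the read-out)), compound 1 gives 27.7%. Compound 2 `CC1=C(C(=O)Nc2ccc([N+](=O)[O-])cc2)C(c2ccc(Br)cc2)N=C(SCc2ccc(Cl)cc2)N1` carries chloro in place of hydrogen on an aromatic carbon, and in this assay compound 2 gives 29.7%. The step of a number 2 percentage points higher from compound 1 to compound 2 (within the scatter) lies within the scatter. Of the two numbers, compound 2 is nominally the higher, but the gap to compound 1 is within the scatter, so the two stand together rather than in order.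

Compound 3 `CC1=C(C(=O)Nc2ccc([N+](=O)[O-])cc2)C(c2ccc(Br)cc2)N=C(SCc2ccc(F)cc2)N1` has not yet been measured in this assay. Its difference from compound 2 is fluoro in place of chloro on an aromatic carbon. For the measured compounds named here, the only measured step touching this position, the move from hydrogen to chloro, was a number 2 percentage points higher from compound 1 to compound 2 (within the scatter), within the scatter, and no step from chloro to fluoro is known. The expected step is therefore no change beyond the scatter, a number 1.2 percentage points lower from compound 2 to compound 3 (within the scatter). For compound 3 in this assay the estimate is 28.5%, with a range from 18% to 39%.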

Compound 3, a percentage reported as inhibition, in the whole organism at one dose (the size of the read-out at that dose, not a potency): 27.2%
Beside the measured number, compound 3's estimate is 1.3 percentage points above it, within the range that was stated.
By their numbers in this assay, from the lowest: compounds 3, 1 and 2 (each within the scatter of the next).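

In this assay, fluoro in place of chloro gives a number 2.5 percentage points lower from compound 2 to compound 3 (within the scatter), and fluoro in place of hydrogen gives a number 0.5 percentage points lower from compound 1 to compound 3 (within the scatter). Until now this aromatic carbon had been probed only by the step from hydrogen to chloro; with a second halogen in the comparison, hydrogen, chloro and fluoro all stand together, and the read-out at this one dose does not separate any pair of them. No measurement shown here offers an explanation for this result.

The three compounds leave open whether a group of another kind on this aromatic carbon, such as a methoxy group, an amine or a carboxylic acid, would move the number beyond the scatter. They also leave open whether the benzylsulfanyl arm matters at all, for instance whether a longer chain between the sulfur and the aromatic ring, or a plain methylsulfanyl group in place of the benzylsulfanyl group, would give a different reading on the shared core.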